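A Larger Group on the Ring Nitrogen of Compound 3

A few compounds are considered here, and "the series" means these few. Any claim that something is new, unique, unknown or untested is made for them only; others in the source may bear on it.

Of the compounds shown here, three built on one shared core have been measured in a functional assay on HCC827 cells (Homo sapiens) for antiproliferative activity, read by sulforhodamine B assay, with a stated time of 72 h; on this read-out lower numbers stand for stronger inhibition and higher numbers for weaker inhibition. Compound 1 `CN(CCNCc1cn(-c2ccc(Br)cc2)nn1)CCNc1ccnc2cc(Cl)ccc12` gives 11000 nM. Compound 2 `CN(CCNCc1cn(Cc2ccccc2)nn1)CCNc1ccnc2cc(Cl)ccc12` gives 16000 nM. Compound 3 `CN(CCNCc1cn(C(C)(C)C)nn1)CCNc1ccnc2cc(Cl)ccc12` gives 56000 nM, the highest of the three numbers: the steps of a 5.1-fold higher number from compound 1 to compound 3 (0.71 log units; beyond the scatter) and a 3.5-fold higher number from compound 2 to compound 3 (0.54 log units; beyond the scatter) both lie beyond the scatter, whereas a 1.5-fold higher number from compound 1 to compound 2 (0.16 log units; within the scatter) does not, so compound 1 and compound 2 cannot be ordered against each other.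

Compound 4 `CN(CCNCc1cn(CCC(=O)Nc2ccccn2)nn1)CCNc1ccnc2cc(Cl)ccc12` differs from compound 3 in one place: 2-((pyridin-2-yl)carbamoyl)ethyl in place of tert-butyl on an aromatic nitrogen. The two measured steps that bear on this change are the ones arriving at compound 3, in which tert-butyl took the place of a group carrying a six-membered aromatic ring and the number rose by a modest amount each time. The entering group in compound 4 again carries a six-membered aromatic ring, though now at the end of a chain with an amide. Because a 5.1-fold higher number from compound 1 to compound 3 (0.71 log units; beyond the scatter) and a 3.5-fold higher number from compound 2 to compound 3 (0.54 log units; beyond the scatter) both moved upward on leaving such groups, the reverse direction is expected for compound 4, a modest lowering, a 3.7-fold lower number from compound 3 to compound 4 (0.57 log units; beyond the scatter). What the chain and the amide contribute cannot be read from the three measured compounds. Compound 4 is therefore expected to give about 15000 nM, within a range from 5000 nM to 45000 nM.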

Compound 4, half-maximal inhibitory concentration: > 200000 nM
Compound 4: a limit, no number; the forecaster's own chance of this, stated with the estimate: 10%; at least 13-fold (1.12 log units) between middle value and limit.
By their numbers in this assay, from the lowest: compounds 1 and 2 (each within the scatter of the next); then compound 3. At a limit, above all of these: compound 4.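

Compound 4 stands at a limit of this assay, not at a number: the limit of > 200000 nM in this assay, at which 1 of the 4 values shown sits. The position on the aromatic nitrogen therefore does not simply favour an entering group with a six-membered aromatic ring, since 2-((pyridin-2-yl)carbamoyl)ethyl carries one and the change from tert-butyl still gives an at least 3.5-fold higher number from compound 3 to compound 4 (0.55 log units; beyond the scatter). Against the two groups with a six-membered aromatic ring in the earlier compounds the steps are large, with an at least 12-fold higher number from compound 2 to compound 4 (1.09 log units; beyond the scatter) and an at least 18-fold higher number from compound 1 to compound 4 (1.25 log units; beyond the scatter), so this one change moves the read-out further than any step among compounds 1, 2 and 3 did.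

The compounds shown leave open which part of the entering group goes with this rise, as the chain, the amide and the pyridine ring all enter together in compound 4, and how far its true value lies past the limit also stays unknown. A plain phenyl ring on the same chain, or a carboxylic acid or an amine at the end of a chain, would be needed to tell these parts apart.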